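This account rests on a few compounds, and the source may have more. Where it says the series, first, only, none or still open, it means among the compounds named here.

Measured compounds in a functional assay on K562 cells (Homo sapiens) for cytotoxicity, read by MTT assay, with a stated time of 72 h; on this read-out lower numbers stand for higher toxicity in this test and higher numbers for lower toxicity in this test:
- compound 1 `CS/C(=N\C(=O)c1csc([N+](=O)[O-])c1)NC(=O)c1csc([N+](=O)[O-])c1`: > 100000 nM (a limit of the assay)
- compound 2 `O=C(/N=C(/NC(=O)c1cccs1)[Se]Cc1ccccc1)c1cccs1`: 87400 nM
- compound 3 `CS/C(=N\C(=O)c1cccs1)NC(=O)c1cccs1`: > 100000 nM (a limit of the assay)

Compound 1 and compound 3 share the pattern of two acylated nitrogens on one carbon; how their cores differ is not broken down here. Compound 1 is measured only as a limit. Compound 3 likewise reaches only a limit. From compound 3 to compound 2 the change a group of 8 heavy atoms (7 carbon, 1 selenium; one six-membered aromatic ring of carbon only) in place of a group of 2 heavy atoms (1 carbon, 1 sulfur; no ring), on a carbon with a double bond to nitrogen gave an at least 1.1-fold lower number from compound 3 to compound 2 (0.05 log units; that floor lies within the scatter), a step bounded by the limit of > 100000 nM in this assay, at which 2 of the 3 values shown sit.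

Compound 4 `O=C(/N=C(/NC(=O)c1csc([N+](=O)[O-])c1)[Se]Cc1ccccc1)c1csc([N+](=O)[O-])c1` arises from compound 1 by a group of 8 heavy atoms (7 carbon, 1 selenium; one six-membered aromatic ring of carbon only) in place of a group of 2 heavy atoms (1 carbon, 1 sulfur; no ring), on a carbon with a double bond to nitrogen, the same kind of change at a place described in the same words. Because the earlier case gave an at least 1.1-fold lower number from compound 3 to compound 2 (0.05 log units; that floor lies within the scatter) the expected step is an at least 1.1-fold lower number from compound 1 to compound 4 (0.04 log units; that floor lies within the scatter). Compound 4 is thus estimated at 90000 nM, with 40000 nM to 200000 nM as the expected range, and a limit rather than a number remains a real possibility.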

Compound 4, concentration lethal to 50% of the cells: 88200 nM
Compound 4: the middle estimate sits 1.0-fold (0.01 log units) above what was measured; the measured number falls inside the stated range.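

Replacing methylsulfanyl with the selenium-containing group, on a carbon with a double bond to nitrogen, gives an at least 1.1-fold lower number from compound 1 to compound 4 (0.05 log units; that floor lies within the scatter) in this assay. As far as the data can be read, this change behaves alike on the two cores: the same change on two cores in this assay, an at least 1.1-fold lower number (0.05 log units; that floor lies within the scatter) from compound 3 to compound 2 and an at least 1.1-fold lower number (0.05 log units; that floor lies within the scatter) from compound 1 to compound 4; the limit leaves it open whether they differ

Neither step is shown to lie beyond the scatter, so carrying the change across cores is consistent but is not shown to lower the number by a real margin, and the full size of each step remains unknown: the limit of > 100000 nM in this assay, at which 2 of the 4 values shown sit.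

Still open, on these data alone, is how an amine or a longer chain would behave at this carbon on either core. Also open, as far as these compounds go, is whether any such group would give a number clearly separated from the assay limit.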